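A few compounds are considered here, and "the series" means these few. Any claim that something is new, unique, unknown or untested is made for them only; others in the source may bear on it.

Compound 2 `COc1c(O)ccc(/C=C/C2(C)C=CC(=O)O2)c1OC` and compound 1 `COc1ccc(/C=C/C2(C)C=CC(=O)O2)c(OC)c1OC` share one core and differ only by methyl in place of hydrogen on an oxygen on an aromatic ring. In a functional assay on UACC-62 cells (Homo sapiens) for inhibition, read by sulforhodamine B assay, with a stated time of 48 h (a lower number here means a stronger inhibitor of growth, a higher number a weaker inhibitor of growth), compound 2 gives 24600 nM, while compound 1 gives 71500 nM, so that change made a 2.9-fold higher number from compound 2 to compound 1 (0.46 log units; beyond the scatter). Compound 3 `CC1(/C=C/c2ccccc2O)C=CC(=O)O1` rests on a different core; how its core differs from that of compound 2 is not broken down here. In this assay compound 3 gives 92500 nM. Compound 4 `COc1ccccc1/C=C/C1(C)C=CC(=O)O1` is compound 3 with methyl in place of hydrogen on an oxygen on an aromatic ring, the same change as the one just described, at a place told in the same words. Among the measured compounds shown here, the step here is expected to be about a 2.4-fold higher number from compound 3 to compound 4 (0.38 log units; beyond the scatter), resting on the earlier change, which gave a 2.9-fold higher number from compound 2 to compound 1 (0.46 log units; beyond the scatter), with no second example to show whether it carries over to this core. Compound 4 is therefore expected to give roughly 220000 nM in this assay, somewhere between 90000 nM and 550000 nM.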

Compound 4, concentration for total growth inhibition: 31000 nM
For compound 4 the middle estimate is 7.1-fold (0.85 log units) above the measured one; the measured number lies below the stated range.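

In this assay the change from hydroxy to methoxy gave a 3.0-fold lower number from compound 3 to compound 4 (0.47 log units; beyond the scatter) and so ran the opposite way to the same change on the other core. The two steps therefore do not agree: the same change on two cores in this assay, a 2.9-fold higher number (0.46 log units; beyond the scatter) from compound 2 to compound 1 and a 3.0-fold lower number (0.47 log units; beyond the scatter) from compound 3 to compound 4, 8.7-fold (0.94 log units) apart, beyond the scatter of two such steps. Among the compounds shown here, this shows that the effect of the change on one core cannot simply be carried to another, but with only two examples it does not show which difference between the cores matters or what a third core would do.

The compounds shown leave open how an ethyl or a longer chain on that oxygen would behave. They also leave open whether an amine in place of the hydroxy would follow either direction.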